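The compounds below may be only part of what the source reports. "The series", "measured", "known", "first", "only" and "open" are said of these compounds alone.

Working notes on a small dithiocarbamate set, all tested in a functional assay on MDA-MB-435S cells (Homo sapiens) for antiproliferative activity, read by MTT assay, with a stated time of 72 h; a higher number here means a weaker inhibitor, a lower number a stronger inhibitor.

Compound 1 `O=c1cc(CSC(=S)N2CCCC2)oc2cc(Cl)ccc12` carries a pyrrolidin-1-yl group on the thiocarbonyl carbon. In this assay compound 1 returns only the limit of the assay, > 25000 nM, and not a number. Compound 3 `CC(C)N(C(=S)SCc1cc(=O)c2ccc(Cl)cc2o1)C(C)C` has the same core as compound 1 but a diisopropylamino group on the thiocarbonyl carbon. In this assay compound 3 likewise sits at the limit, > 25000 nM, with no number read. The change from compound 3 to compound 1 is pyrrolidin-1-yl in place of diisopropylamino on a thiocarbonyl carbon. Its size is therefore a step that the two limits leave unreadable from compound 3 to compound 1, because both ends rest on (the limit of > 25000 nM in this assay, at which 2 of the 3 values shown sit).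

Compound 2 `CC(C)N(C(=S)SCc1oc2ccccc2c(=O)c1Cl)C(C)C` is built from the same atoms as compound 3, joined differently; the difference between the two cores is not broken down here. In this assay, going by the values given here, compound 2 gives 23600 nM, the only actual number in the set.

Compound 4 `O=c1c(Cl)c(CSC(=S)N2CCCC2)oc2ccccc12` is to be measured in this assay. It stands to compound 2 as compound 1 stands to compound 3: pyrrolidin-1-yl in place of diisopropylamino on a thiocarbonyl carbon, the same kind of change, with the place described in the same words. Since the earlier step is unreadable and compound 2 already lies close to the limit, the step from compound 2 to compound 4 is expected to be about flat, a 1.1-fold higher number from compound 2 to compound 4 (0.03 log units; within the scatter). Compound 4 is accordingly estimated at 25000 nM, within a range of 12000 nM to 50000 nM, with a fair chance that only a limit is reported.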

Compound 4, half-maximal inhibitory concentration: 1800 nM
Estimate against measurement, compound 4: 14-fold (1.14 log units) above, outside the stated range (below it).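

In this assay, pyrrolidin-1-yl in place of diisopropylamino on a thiocarbonyl carbon gives a 13-fold lower number from compound 2 to compound 4 (1.12 log units; beyond the scatter), so on the core shared by compound 2 and compound 4 this change carries a large step. On the core shared by compound 3 and compound 1, the same change cannot be read, because both ends of that step rest on a limit of the assay and not on a number: the limit of > 25000 nM in this assay, at which 2 of the 4 values shown sit. The series therefore holds one readable instance of the change, which shows what it does on one core but neither that the step carries over to the other core nor that it fails to, since a step of any size may lie hidden behind the two limits.

Still open, on these data alone, is whether another amine on the thiocarbonyl carbon, such as piperidin-1-yl, morpholin-4-yl or dimethylamino, would follow pyrrolidin-1-yl on the core of compound 4, or whether the step belongs to pyrrolidin-1-yl alone. Also open, as far as these compounds go, is how much of the result depends on the chlorine of that core, which a compound with bromine or methyl in its place would begin to test.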